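Amine variation and a methoxy addition: expectation for compound 4

The source may report more compounds than this note shows. Statements on the series, on what has been measured and on what is new or still open speak of the compounds shown alone.

Measured so far in an assay on isolated protein for inhibition of Amine oxidase [flavin-containing] A (Homo sapiens), read by fluorescence, with a stated time of 30 min, tested at 20 uM; on this read-out lower numbers stand for less inhibition and higher numbers for more inhibition at the one concentration tested (going by the name of the read-out):
compound 1 `CCN(CC)Cc1ccc(/C=C2\COc3cc(OC)c(OC)cc3C2=O)cc1O`: 9.5%
compound 2 `COc1cc2c(cc1OC)C(=O)/C(=C/c1ccc(CN3CCCC3)c(O)c1)CO2`: 16.4%
compound 3 `COc1cc2c(cc1OC)C(=O)/C(=C/c1ccc(CN(C)Cc3ccccc3)c(O)c1)CO2`: 3.4%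

Compound 3 stands lowest of the three numbers. The step of a number 6.1 percentage points lower from compound 1 to compound 3 (within the scatter) is within the scatter, whereas a number 13 percentage points lower from compound 2 to compound 3 (beyond the scatter) is beyond it, so only compound 2 is clearly separated from compound 3. The remaining step, a number 6.9 percentage points higher from compound 1 to compound 2 (within the scatter), is also within the scatter.

Compound 4 `COc1ccccc1CN(C)Cc1ccc(/C=C2\COc3cc(OC)c(OC)cc3C2=O)cc1O` differs from compound 3 by methoxy in place of hydrogen on an aromatic carbon. None of the three measured steps touches this position; all of them exchange the amine on the saturated chain carbon bound to an aromatic carbon, and each of those changes is small. Going by the values given here, no measured step therefore bears directly on this change, and for compound 4 no step beyond the scatter is expected, a number 1.6 percentage points higher from compound 3 to compound 4 (within the scatter). Compound 4 is estimated at 5%, with a range from 0% to 15%.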

Compound 4, a percentage reported as inhibition, at one concentration (the size of the read-out at that concentration, not a potency): 12.3%
Estimate against measurement, compound 4: 7.3 percentage points below; the measured number falls inside the stated range.
By their numbers in this assay, from the lowest: compounds 3, 1, 4 and 2 (each within the scatter of the next, the first and the last beyond it).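

In this assay, going by these compounds alone, methoxy in place of hydrogen on an aromatic carbon gives the first reading at this position, and the change from benzyl to 2-methoxybenzyl amounts to a number 8.9 percentage points higher from compound 3 to compound 4 (within the scatter). The (2-methoxybenzyl)(methyl)amino group also stays close to the other amines, with a number 4.1 percentage points lower from compound 2 to compound 4 (within the scatter) and a number 2.8 percentage points higher from compound 1 to compound 4 (within the scatter). Nothing available explains these numbers.

Going by these compounds, whether a different group on this aromatic carbon, such as hydroxy, fluoro or a carboxylic acid, would move the number beyond the scatter remains open.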